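The compounds below may be only part of what the source reports. "The series", "measured", "known", "first", "only" and "open" are said of these compounds alone.

The measured compounds in a functional assay on CHO cells for agonist activity at Alpha-1B adrenergic receptor (Homo sapiens), read by FLIPR and calcium flux; on this read-out higher numbers stand for an effect only at larger amounts of compound and lower numbers for an effect already at smaller amounts:
Compound 1, `Cc1n[nH]cc1-c1cccc2c1CCC2c1ncc[nH]1`, gives 902 nM.
Compound 2, `c1ccc(-c2cccc3c2CCC3c2ncc[nH]2)nc1`, gives only the limit of > 10000 nM.
Compound 3, `COc1c(C)ccc2c1CCC2c1ncc[nH]1`, likewise gives only the limit of > 10000 nM.

Compound 2 thus stands not at a number but at a limit in this assay, a place it shares with one further compound, compound 3. Going by the values given here, the single measured step that reaches compound 2, an at least 11-fold higher number from compound 1 to compound 2 (1.04 log units; beyond the scatter), is large and beyond the scatter, and it ends at the limit of > 10000 nM in this assay, at which 2 of the 3 values shown sit. Compound 4, `CCCS(=O)(=O)Nc1cccc2c1CCC2c1ncc[nH]1`, differs from compound 2 in one place: (propylsulfonyl)amino in place of pyridin-2-yl on an aromatic carbon. Among the compounds with values here, no measured step sets these two groups side by side, and the one step that touches compound 2 tells how far it lies from compound 1, not how far past the limit it sits. Compound 1 does show that a number within reach of the assay occurs on this core. Compound 4 is therefore expected to land near the limit, the estimated step being an at least 1.1-fold lower number from compound 2 to compound 4 (0.04 log units; that floor lies within the scatter). For compound 4 the estimate in this assay is 9000 nM, in a range from 2000 nM to 30000 nM, with a fair chance that again only a limit is reported.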

Compound 4, half-maximal effective concentration: > 10000 nM
Compound 4: no number, only a limit (the forecaster's own chance of this, stated with the estimate: 65%); middle value at least 1.1-fold (0.04 log units) from the limit.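

In this assay compound 4 gives > 10000 nM, which is a limit and not a number. With (propylsulfonyl)amino in place of 3-methyl-1H-pyrazol-4-yl on this aromatic carbon, the result is an at least 11-fold higher number from compound 1 to compound 4 (1.04 log units; beyond the scatter), so a group with no ring ends at the same limit as the ring-bearing pyridin-2-yl, and leaving the range of the assay is no longer tied to a single replacement group. The step between compound 2 and compound 4 cannot be read, both of its ends being limits, and compound 1 remains the only compound here with a number: the limit of > 10000 nM in this assay, at which 3 of the 4 values shown sit.

Going by these compounds, how far past the limit compound 2 and compound 4 lie remains open. So does whether an unsubstituted pyrazol-4-yl, or a small amine on the same aromatic carbon, would give a number on the shared core.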